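From acetyl to carboxymethyl on one aromatic carbon

The compounds below may be only part of what the source reports. "The series", "measured", "known", "first", "only" and "open" are said of these compounds alone.

In a functional assay (mast cells) for inhibition, with Rattus norvegicus as the target (a lower number here means that less compound is needed, a higher number that more compound is needed for the effect), compound 2 (`CC(=O)c1ccc(N/N=C2\CCC(C)n3c2ncc(C(=O)O)c3=O)cc1`) gives 8100 nM and compound 1 (`CC1CC/C(=N\Nc2ccc([N+](=O)[O-])cc2)c2ncc(C(=O)O)c(=O)n21`) gives 8900 nM, so the two stand within the scatter of each other. Compound 3 (`CC1CC/C(=N\Nc2ccc(CC(=O)O)cc2)c2ncc(C(=O)O)c(=O)n21`) has not yet been measured. It differs from compound 2 by carboxymethyl in place of acetyl on an aromatic carbon. Within the data shown here, only one measured step bears on this exchange, a 1.1-fold lower number from compound 1 to compound 2 (0.04 log units; within the scatter), in which acetyl replaced nitro on an aromatic carbon and the result stayed within the scatter. Among the measured compounds shown here, on that single precedent, no shift beyond the scatter is expected in this assay, though no compound with carboxymethyl has been measured. The expected change is an estimated 1.0-fold higher number from compound 2 to compound 3 (0.02 log units; within the scatter). Compound 3 is expected at 8500 nM, with an estimated range from 2500 nM to 30000 nM.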

Compound 3, half-maximal effective concentration: 3400 nM
Estimate against measurement, compound 3: 2.5-fold (0.40 log units) above; measured number inside the range.
By their numbers in this assay, from the lowest: compound 3; then compounds 2 and 1 (each within the scatter of the next).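

In this assay, this place on the aromatic ring, para to a large group, now proves responsive to the group it carries: carboxymethyl in place of acetyl gives a 2.4-fold lower number from compound 2 to compound 3 (0.38 log units; beyond the scatter), and carboxymethyl in place of nitro gives a 2.6-fold lower number from compound 1 to compound 3 (0.42 log units; beyond the scatter). The earlier exchange of acetyl for nitro had stayed within the scatter, so acetyl and nitro could not be told apart here, while carboxymethyl stands apart from both, though only by modest steps. Carboxymethyl also brings a hydrogen-bond donor that acetyl lacks, but nothing available here links that difference, or any other, to the lower number.

The compounds shown leave open whether a longer chain ending in a carboxylic acid would lower the number further. They also do not show whether a methyl ester or an amine on the same chain would match carboxymethyl.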